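Moving the added phenyl ring to a new position

A few compounds are considered here, and "the series" means these few. Any claim that something is new, unique, unknown or untested is made for them only; others in the source may bear on it.

In an assay on a protein complex for binding affinity to integrin alpha-5/beta-1 (Homo sapiens), read by ELISA, with a stated time of 1 h (a lower number here means a stronger inhibitor, a higher number a weaker inhibitor), the three measured compounds stand as follows:
- compound 1, `N=C(N)Nc1cccc(C(=O)NCC(=O)N[C@@H](CC(=O)O)C(=O)NCc2ccccc2)c1`, gives 31 nM
- compound 2, `N=C(N)Nc1cccc(C(=O)NCC(=O)N[C@@H](CC(=O)O)C(=O)NCc2ccc(Cl)cc2)c1`, gives 48 nM
- compound 3, `N=C(N)Nc1cccc(C(=O)NCC(=O)N[C@@H](CC(=O)O)C(=O)NCc2cccc(-c3ccccc3)c2)c1`, gives 18 nM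

Compound 3 has the lowest number of the three, but its separation from compound 1 is small: a 1.7-fold lower number from compound 1 to compound 3 (0.24 log units; within the scatter). Its separation from compound 2 is larger: a 2.7-fold lower number from compound 2 to compound 3 (0.43 log units; beyond the scatter). The chloro substituent alone changes little: a 1.5-fold higher number from compound 1 to compound 2 (0.19 log units; within the scatter).

Compound 4, `N=C(N)Nc1cccc(C(=O)NCC(=O)N[C@@H](CC(=O)O)C(=O)NCc2ccc(-c3ccccc3)cc2)c1`, keeps every atom of compound 3 and rearranges only the outer ring: 4-phenylphenyl in place of 3-phenylphenyl on a saturated chain carbon bound to an amide-type nitrogen. No measured pair compares two positions of the same group, so the direction of this change is not shown by the data. The nearest guide is that a phenyl added to the benzyl ring in compound 3 shifted the number only within the scatter, and that a chloro added at the position now carrying the phenyl in compound 4 also stayed within the scatter in compound 2. Compound 4 is therefore expected to land close to compound 3, with an expected step of a 1.4-fold higher number from compound 3 to compound 4 (0.14 log units; within the scatter) in this assay and no shift beyond the scatter. The estimate for compound 4 in this assay is 25 nM, with a range from 8 nM to 80 nM.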

Compound 4, half-maximal inhibitory concentration: 41 nM
Beside the measured number, compound 4's estimate is 1.6-fold (0.21 log units) below it, within the range that was stated.
By their numbers in this assay, from the lowest: compounds 3, 1, 4 and 2 (each within the scatter of the next, the first and the last beyond it).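

This is the first pair in which one group, a phenyl, is shown at two positions, and in this assay the position makes a measurable difference (a 2.3-fold higher number from compound 3 to compound 4 (0.36 log units; beyond the scatter)). The 3-phenylphenyl and 4-phenylphenyl groups have the same heavy atoms, aromatic rings and hydrogen-bond counts, so the step comes from how the same atoms are joined, and a modest step can arise without any atom being added or removed. The 4-phenylphenyl group, by contrast, stays within the scatter of both the unsubstituted compound (a 1.3-fold higher number from compound 1 to compound 4 (0.12 log units; within the scatter)) and the chloro compound (a 1.2-fold lower number from compound 2 to compound 4 (0.07 log units; within the scatter)), so these compounds do not separate phenyl from hydrogen or from chloro at that position, and nothing shown gives a reason for the gap between the two phenyl placements.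

Going by these compounds, whether a methoxy group, an amine or a carboxylic acid on the ring would show the same dependence on position remains open. So does whether a longer chain in place of the saturated chain carbon bound to the amide-type nitrogen would keep the gap between the two placements.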